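The source may hold more compounds than are shown below. What is called first, only, known or untested is meant among the compounds shown, and "the series" means these compounds.

Measured so far:
Compound 1, `Cc1cc(F)ccc1[C@H]1C[C@@H](N(C)C)CCN1C(=O)N(C)Cc1cc(C(F)(F)F)cc(C(F)(F)F)c1`: 0.0794 nM
Compound 2, `Cc1cc(F)ccc1[C@H]1C[C@@H](N2CCC2)CCN1C(=O)N(C)[C@H](C)c1cc(C(F)(F)F)cc(C(F)(F)F)c1`: 0.178 nM
Compound 3, `Cc1cc(F)ccc1[C@H]1C[C@H](N2CCC2)CCN1C(=O)N(C)[C@H](C)c1cc(C(F)(F)F)cc(C(F)(F)F)c1`: 0.646 nM

All three were tested in an assay on CHO cells for displacement of a labelled ligand from Substance-P receptor (Homo sapiens), read by scintillation counting; a lower number here means a stronger inhibitor, a higher number a weaker inhibitor. Compound 3 gives the highest number of the three, that is, it is the weakest inhibitor among them; its closest neighbour is compound 2, and the change from one to the other is a 3.6-fold higher number from compound 2 to compound 3 (0.56 log units; beyond the scatter), which rests on (the fact that compounds 2 and 3 differ only in the configuration as drawn). Compound 1 stands further away still, with a lower number than compound 3.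

Compound 4, `Cc1cc(F)ccc1[C@H]1C[C@H](N2CCCC2)CCN1C(=O)N(C)[C@H](C)c1cc(C(F)(F)F)cc(C(F)(F)F)c1`, has not yet been measured. It differs from compound 3 in one place: pyrrolidin-1-yl in place of azetidin-1-yl on a saturated ring carbon. Within the data shown here, none of the measured steps concerns a change of this kind; the only measured step, that from compound 2 to compound 3, is a change of configuration and says nothing about the size of the saturated ring on that carbon. With no guide from the data, the expectation for compound 4 is a number close to that of compound 3, a step of a 1.1-fold higher number from compound 3 to compound 4 (0.03 log units; within the scatter), which is within the scatter. Compound 4 is therefore estimated at 0.7 nM, somewhere between 0.25 nM and 2 nM.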

Compound 4, inhibition constant: 0.2 nM
For compound 4 the middle estimate is 3.5-fold (0.54 log units) above the measured one, and the stated range ends above it.
By their numbers in this assay, from the lowest: compound 1; then compounds 2 and 4 (each within the scatter of the next); then compound 3.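

At this saturated ring carbon, three ring bonds from the ring nitrogen, the size of the ring on the substituent matters: in this assay, replacing the four-membered azetidin-1-yl with the five-membered pyrrolidin-1-yl gives a 3.2-fold lower number from compound 3 to compound 4 (0.51 log units; beyond the scatter) and so a stronger inhibitor. The earlier step at this carbon changed only its configuration, whereas this one shows that changing the group itself also moves the number, and that the larger ring is accepted here. Nothing in the data explains why this step goes in this direction.

The compounds shown leave open whether the same ring change would have a similar effect with the configuration of compound 2 at this carbon. They also leave open how a piperidin-1-yl or morpholin-4-yl group would compare with pyrrolidin-1-yl at this position.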